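This account rests on a few compounds, and the source may have more. Where it says the series, first, only, none or still open, it means among the compounds named here.

Of the compounds shown here, three sharing one core have been tested in a functional assay on HT-29 cells (Homo sapiens) for cytotoxicity, read by sulforhodamine B assay; on this read-out lower numbers stand for stronger inhibition and higher numbers for weaker inhibition. Compound 1 `C=C1[C@@H](OC(C)=O)C[C@@H]2[C@](C)(COC=O)[C@H](OC(C)=O)CC[C@@]2(C)[C@@H]1C[C@@H](Nc1ccccc1F)C1=CCOC1=O` gives 9760 nM, compound 2 `C=C1[C@@H](OC(C)=O)C[C@@H]2[C@](C)(CO[Si](C)(C)C(C)(C)C)[C@H](OC(C)=O)CC[C@@]2(C)[C@@H]1C[C@@H](Nc1ccccc1F)C1=CCOC1=O` gives 3710 nM, and compound 3 `C=C1[C@@H](OC(C)=O)C[C@@H]2[C@](C)(COC=O)[C@H](OC(C)=O)CC[C@@]2(C)[C@@H]1C[C@@H](Nc1ccc(Br)cc1)C1=CCOC1=O` gives 13200 nM. Compound 2 stands lowest of the three: the change a 2.6-fold lower number from compound 1 to compound 2 (0.42 log units; beyond the scatter) brought its number down, and it also sits below compound 3. Compound 4 `C=C1[C@@H](OC(C)=O)C[C@@H]2[C@](C)(CO[Si](C)(C)C(C)(C)C)[C@H](OC(C)=O)CC[C@@]2(C)[C@@H]1C[C@@H](Nc1ccc(OC)cc1)C1=CCOC1=O` differs from compound 2 in one place: 4-methoxyphenyl in place of 2-fluorophenyl on an amine nitrogen. Within the data shown here, the one measured step that also swaps the group on the amine nitrogen is a 1.4-fold higher number from compound 1 to compound 3 (0.13 log units; within the scatter), which stayed within the scatter. A similar outcome is expected here, so the estimated step is a 1.2-fold higher number from compound 2 to compound 4 (0.08 log units; within the scatter), with no clear direction. Compound 4 is thus expected to give about 4500 nM, between 1800 nM and 11000 nM.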

Compound 4, half-maximal inhibitory concentration: 5370 nM
For compound 4 the middle estimate is 1.2-fold (0.08 log units) below the measured one; the measured number falls inside the stated range.
By their numbers in this assay, from the lowest: compounds 2, 4, 1 and 3 (each within the scatter of the next, the first and the last beyond it).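

Replacing 2-fluorophenyl with 4-methoxyphenyl on the amine nitrogen gives a 1.4-fold higher number from compound 2 to compound 4 (0.16 log units; within the scatter) in this assay. Together with a 1.4-fold higher number from compound 1 to compound 3 (0.13 log units; within the scatter), this makes two swaps of the aromatic group at this position, on two different versions of the shared core, and neither moves the number beyond the scatter. No other measurement shown bears on this result. The compounds shown leave open whether this nitrogen would accept something other than a substituted phenyl ring, such as a cyclohexyl group, a longer alkyl chain, or a phenyl carrying a carboxylic acid.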